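Ether-to-thioether swap on a diaminoquinoxaline core

This account rests on a few compounds, and the source may have more. Where it says the series, first, only, none or still open, it means among the compounds named here.

The shared core of compound 1 `Nc1cc(N)c2nc(-c3ccccc3)c(Oc3ccc(Cl)c(Cl)c3)nc2c1` appears in three measured compounds, and in a functional assay on Malme-3M cells (Homo sapiens) for inhibition, read by sulforhodamine B assay, with a stated time of 48 h (a lower number here means a stronger inhibitor of growth, a higher number a weaker inhibitor of growth), compound 1 gives 37200 nM. Compound 2 `CCOC(=O)[C@H](CCC(=O)O)NC(=O)c1ccc(Sc2nc3cc(N)cc(N)c3nc2-c2ccccc2)cc1` gives 37200 nM in this assay, and compound 3 `CCOC(=O)[C@H](CCC(=O)O)NC(=O)c1ccc(Oc2nc3cc(N)cc(N)c3nc2-c2ccccc2)cc1` gives 35500 nM. Compound 1 is level with compound 2 at the digits shown, the two together standing at the top of the three readings, and its gap to compound 3 is also within the scatter, so no order among the three can be stated. Compound 2 and compound 3 differ from each other in one position and return readings within the scatter of one another; no step between them is listed here, so only that agreement is noted.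

Compound 4 `Nc1cc(N)c2nc(-c3ccccc3)c(Sc3ccc(Cl)c(Cl)c3)nc2c1` is the unmeasured partner of compound 1; the change is (3,4-dichlorophenyl)sulfanyl in place of 3,4-dichlorophenoxy on an aromatic carbon. Within the data shown here, no step between two measured compounds covers this kind of change. Given that all three measured readings fall together, and that compound 2 with 37200 nM and compound 3 with 35500 nM show no separation, the expected step of a 1.0-fold lower number from compound 1 to compound 4 (0.00 log units; within the scatter) is none beyond the scatter. Compound 4 is therefore estimated at 37000 nM, with a range from 18000 nM to 75000 nM.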

Compound 4, concentration for total growth inhibition: 50100 nM
Compound 4: the middle estimate sits 1.4-fold (0.13 log units) below what was measured, and the stated range covers the measured number.
By their numbers in this assay, from the lowest: compounds 3, 1, 2 and 4 (each within the scatter of the next).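

In this assay, among these compounds, placing (3,4-dichlorophenyl)sulfanyl in place of 3,4-dichlorophenoxy, on the aromatic carbon next to the ring nitrogen and ortho to the phenyl group, gives a 1.3-fold higher number from compound 1 to compound 4 (0.13 log units; within the scatter) as the first directly read step for this exchange at this position. With the 3,4-dichlorophenyl group attached, the exchange of the linking oxygen for sulfur therefore produces no separation in this assay, and compound 3 at 35500 nM and compound 2 at 37200 nM likewise show no separation with their larger side group, so the two pairs agree on this point. No measurement at hand bears on what lies behind this agreement.

The compounds shown leave open whether a different link at this carbon, such as an amine nitrogen or a methylene in place of the oxygen or sulfur, would give a reading separated from this level. Also open, from the compounds shown here alone, is whether a carboxylic acid on the outer aromatic ring, in place of the chlorine atoms, would separate from these readings.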